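Cyanophenyl versus cyanomethyl on the triazole nitrogen

The source may report more compounds than this note shows. Statements on the series, on what has been measured and on what is new or still open speak of the compounds shown alone.

Measured compounds:
compound 1 `Cc1cc(C)c(Oc2cc(Nc3ccc(C#N)cc3)ncc2C(=O)NCc2cn(Cc3ccccc3C#N)nn2)c(C)c1` — > 219000 nM
compound 2 `Cc1cc(C)c(Oc2cc(Nc3ccc(C#N)cc3)ncc2C(=O)NCc2cn(CCC#N)nn2)c(C)c1` — 40200 nM

Compound 1 `Cc1cc(C)c(Oc2cc(Nc3ccc(C#N)cc3)ncc2C(=O)NCc2cn(Cc3ccccc3C#N)nn2)c(C)c1` reaches only a limit in an ADME assay on MT4 cells (Homo sapiens) for cytotoxicity, read by MTT assay, with a stated time of 5 days (a lower number here means that less compound is tolerated, a higher number that more compound is tolerated), namely > 219000 nM (the limit of > 219000 nM in this assay, at which 1 of the 2 values shown sits). Compound 2 `Cc1cc(C)c(Oc2cc(Nc3ccc(C#N)cc3)ncc2C(=O)NCc2cn(CCC#N)nn2)c(C)c1` gives 40200 nM in this assay, the only number shown among the two values. Among the measured compounds shown here, the one measured step, an at least 5.4-fold lower number from compound 1 to compound 2 (0.73 log units; beyond the scatter), runs from the limit to this number and is beyond the scatter.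

Compound 3 `Cc1cc(C)c(Oc2cc(Nc3ccc(C#N)cc3)ncc2C(=O)NCc2cn(Cc3cccc(C#N)c3)nn2)c(C)c1` carries the change (3-cyanophenyl in place of cyanomethyl on a saturated chain carbon bound to an aromatic nitrogen). This reverses the direction of the measured step, with the nitrile moved around the ring. The step from compound 1 to compound 2 therefore bears directly on it, and a return toward the limit in this assay is expected: the estimated step is a 3.7-fold higher number from compound 2 to compound 3 (0.57 log units; beyond the scatter). Compound 3 is accordingly expected to give 150000 nM, within 50000 nM to 300000 nM, with a fair chance that only a limit is reported.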

Compound 3, half-maximal cytotoxic concentration: >= 129000 nM
Compound 3 ended at the assay's limit; the forecaster's own chance of this, stated with the estimate: 50%; the middle value lies beyond the limit too.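

At this position, on a saturated chain carbon bound to an aromatic nitrogen, 3-cyanophenyl in place of cyanomethyl gives an at least 3.2-fold higher number from compound 2 to compound 3 (0.50 log units; beyond the scatter) in this assay, so the earlier step is not tied to 2-cyanophenyl alone. Compound 3 stops at a limit, not at a number: the limit of >= 129000 nM in this assay, at which 1 of the 3 values shown sits. Among these three, compound 1 and compound 3, both with a cyanophenyl group, end at limits, and only compound 2, with cyanomethyl, gives a number; the step between the two limits cannot be read, so the two placements of the nitrile on the ring remain unordered.

Going by these compounds, what remains open is whether the ring or the nitrile carries the step, which an unsubstituted phenyl would help to separate. On these data alone, it is also open how a longer chain ending in a nitrile, or a chain ending in an amine, would read in this assay.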